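This account rests on a few compounds, and the source may have more. Where it says the series, first, only, none or still open, it means among the compounds named here.

Compound 1 `COc1ccc2c(OCC[C@@H]3NC(=O)N(C)CCCC/C=C\[C@@H]4C[C@@]4(C(=O)NS(=O)(=O)C4(C#N)CC4)NC3=O)cc(-c3nc(C(C)C)cs3)nc2c1Cl` was examined in an ADME assay on cells (Homo sapiens) for activation; a lower number here means that less compound is tolerated, a higher number that more compound is tolerated. There compound 1 reached only the limit of the measurement, > 75000 nM, so no number is known for it, only that it sits at the limit of > 75000 nM in this assay, at which 1 of the 3 values shown sits. Two related compounds give numbers in this assay: compound 2 `COc1ccc2c(OCC[C@@H]3NC(=O)N(C)CCCCC/C=C\[C@@H]4C[C@@]4(C(=O)NS(=O)(=O)C4CC4)NC3=O)cc(-c3ccccc3)nc2c1` gives 53000 nM, and compound 3 `COc1ccc2c(OCC[C@@H]3NC(=O)N(C)CCCC/C=C\[C@@H]4C[C@@]4(C(=O)NS(=O)(=O)C4(C)CC4)NC3=O)cc(-c3nc(C(C)C)cs3)nc2c1` gives 6500 nM, a lower value than compound 2 shows. Compound 1 thus stands at the upper edge of what this assay can report, while the other two compounds fall below that edge.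

Compound 4 `CCC1(S(=O)(=O)NC(=O)[C@@]23C[C@H]2/C=C\CCCCN(C)C(=O)N[C@@H](CCOc2cc(-c4nc(C(C)C)cs4)nc4c(Cl)c(OC)ccc24)C(=O)N3)CC1` has not yet been measured in this assay. It differs from compound 1 in one place: ethyl in place of cyano on a saturated ring carbon. The change touches only the group attached to the sulfonyl-bearing three-membered ring, and the rest of the molecule is the same as in compound 1.

Among the measured compounds shown here, with compound 1 at the limit, no measured step is available for the exchange of cyano against ethyl, and the expectation for compound 4 rests on compound 1 alone. Compound 4 is expected to come out near 60000 nM, within a span from 20000 nM to 150000 nM. The step that this estimate means, an at least 1.2-fold lower number from compound 1 to compound 4 (0.09 log units; that floor lies within the scatter), is expected to be small, with a good chance that this assay again reports only a limit.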

Compound 4, half-maximal cytotoxic concentration: 49300 nM
Compound 4: the middle estimate sits 1.2-fold (0.09 log units) above what was measured; measured number inside the range.
By their numbers in this assay, from the lowest: compound 3; then compounds 4 and 2 (each within the scatter of the next). At a limit, above all of these: compound 1.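

In this assay, with ethyl in place of cyano on this saturated ring carbon, compound 4 gives 49300 nM. This change amounts to an at least 1.5-fold lower number from compound 1 to compound 4 (0.18 log units; that floor lies within the scatter), which fixes only a floor for the step, so the exchange could be anything from a small shift to a much larger one. Compound 1 remains a limit and not a number, and the step therefore has no upper bound: the limit of > 75000 nM in this assay, at which 1 of the 4 values shown sits.

Going by these compounds, how large the step truly is stays open, as does whether it follows from the loss of the nitrile or from the presence of the ethyl itself. Also open, on these data alone, is how this assay would read with a longer chain such as propyl, or with an amine or a carboxylic acid, on the same saturated ring carbon of the core of compound 1.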